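A few compounds are considered here, and "the series" means these few. Any claim that something is new, unique, unknown or untested is made for them only; others in the source may bear on it.

Working notes on the series. Of the compounds shown here, three have been measured in a functional assay on L1210 cells (Mus musculus), with a stated time of 12 days; a lower number here means a less potent compound, a higher number a more potent compound, by a factor of ten per unit of this negative logarithm. Compound 1, `CCOC(COC(N)=O)C1=C(N2CC2)C(=O)C(C)=C(N2CC2)C1=O`, gives 6.18. Compound 2, `CCC1=C(N2CC2)C(=O)C(C(COC(N)=O)OC)=C(N2CC2)C1=O`, gives 6.16. Compound 3, `CCC1=C(N2CC2)C(=O)C(CCOC(N)=O)=C(N2CC2)C1=O`, gives 6.25, the highest of the three numbers, though its gaps to compound 1 and to compound 2 both lie within the scatter, so no order among the three can be claimed. For the measured compounds named here, the only step measured at a single place, a number 0.09 log units higher from compound 2 to compound 3 (within the scatter), concerns the same place as the change now considered. Compound 4, `CCOC(COC(N)=O)C1=C(N2CC2)C(=O)C(CC)=C(N2CC2)C1=O`, differs from compound 3 as follows: ethoxy in place of hydrogen on a saturated chain carbon bound to a double-bonded ring carbon and a saturated chain carbon. This runs opposite to the measured step, with ethoxy entering where methoxy had left, and the measured step was itself within the scatter. Compound 1 carries the same ethoxy group at that place, and its value sits within the scatter of compound 3. Compound 4 is thus expected to show a step of a number 0.05 log units lower from compound 3 to compound 4 (within the scatter), nothing beyond the scatter. The estimate for compound 4 is 6.2, with a range from 5.85 to 6.55.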

Compound 4, logarithm of the reciprocal of the active concentration, log(1/C): 5.76
Beside the measured number, compound 4's estimate is 0.44 log units above it, and the stated range ends above it.
By their numbers in this assay, from the lowest: compound 4; then compounds 2, 1 and 3 (each within the scatter of the next).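

In this assay, ethoxy in place of hydrogen gives a number 0.49 log units lower from compound 3 to compound 4 (beyond the scatter) and so opens the first gap beyond the scatter at this place, where a number 0.09 log units higher from compound 2 to compound 3 (within the scatter) for hydrogen in place of methoxy had shown no readable change. The added methyl also counts here: a number 0.40 log units lower from compound 2 to compound 4 (beyond the scatter) comes with methyl in place of hydrogen on a saturated chain carbon bound to an oxygen on a saturated carbon, so methoxy and ethoxy are told apart at this place. This is not the only place that counts, as a number 0.42 log units lower from compound 1 to compound 4 (beyond the scatter) comes with methyl in place of hydrogen on a saturated chain carbon bound to a double-bonded ring carbon.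

From the compounds shown here alone, whether propoxy or an amine at this place would lie lower still remains open. Nothing measured here gives a reason for these steps.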